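Removing the methoxy from an aminothiazole anilide pair

The compounds below may be only part of what the source reports. "The series", "measured", "known", "first", "only" and "open" are said of these compounds alone.

Compound 1, `COc1ccc(C(=O)c2sc(Nc3ccccc3)nc2N)cc1OC`: > 10000 nM in a functional assay on FM3A cells (Mus musculus) for antiproliferative activity, read by cell counting, with a stated time of 2 days (on this read-out higher numbers stand for weaker inhibition and lower numbers for stronger inhibition), a limit of the assay.
Compound 2, `COc1ccc(Nc2nc(N)c(C(=O)c3ccc(OC)c(OC)c3)s2)cc1`: 71 nM in this assay.
Compound 3, `COc1ccc(C(=O)c2sc(Nc3ccc(Cl)cc3)nc2N)cc1`: > 10000 nM in this assay, a limit of the assay.

Compound 1 differs from compound 2 by hydrogen in place of methoxy on an aromatic carbon, and this change costs an at least 140-fold higher number from compound 2 to compound 1 (2.14 log units; beyond the scatter). The size of that step is known only as a lower bound, since compound 1 sits at the limit of > 10000 nM in this assay, at which 2 of the 3 values shown sit. How the core of compound 3 differs from that of compound 2 is not broken down here; compound 3 is itself only known as a limit.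

Compound 4, `Nc1nc(Nc2ccc(Cl)cc2)sc1C(=O)c1ccccc1`, is not yet measured. It differs from compound 3 by hydrogen in place of methoxy on an aromatic carbon, the same change that turned compound 2 into compound 1. Because compound 3 already stands at the limit of > 10000 nM in this assay, at which 2 of the 3 values shown sit, and the earlier change gave an at least 140-fold higher number from compound 2 to compound 1 (2.14 log units; beyond the scatter), no gain is expected from compound 3 to compound 4; the expected step is a step that the limit leaves unreadable from compound 3 to compound 4, most likely again reported only as a limit. In this assay compound 4 is therefore estimated at 30000 nM, expected to fall between 10000 nM and 200000 nM.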

Compound 4, half-maximal inhibitory concentration: > 10000 nM
Compound 4: no number, only a limit; the forecaster's own chance of this, stated with the estimate: 90%; the middle value does not contradict the limit.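

In this assay compound 4 gives > 10000 nM, a limit of the assay. The step from compound 3 to compound 4 cannot be read, since both compounds stand at a limit: the limit of > 10000 nM in this assay, at which 3 of the 4 values shown sit.

The compounds shown leave open whether the change from 4-methoxyphenyl to phenyl alters activity at all in the setting of compound 3.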